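The source may hold more compounds than are shown below. What is called first, only, known or untested is meant among the compounds shown, and "the series" means these compounds.

Measured in a functional assay on HT cells (Homo sapiens) for antiproliferative activity, read by fluorescence, with a stated time of 72 h; on this read-out higher numbers stand for weaker inhibition of growth and lower numbers for stronger inhibition of growth:
- Compound 1 `CC(C)c1n[nH]c2c(NCc3ccc(-c4ccccn4)cc3)nc(SCC(O)CN)nc12`: 55 nM
- Compound 2 `CC(C)c1n[nH]c2c(NCc3ccc(-c4ccccn4)cc3)nc(SC3CCCC3O)nc12`: 567 nM
- Compound 3 `CC(C)c1n[nH]c2c(NCc3ccc(-c4ccccn4)cc3)nc(SCCNC(N)=O)nc12`: 240 nM

Compound 3 holds the middle of the three values, with a 2.4-fold lower number from compound 2 to compound 3 (0.37 log units; beyond the scatter) and a 4.4-fold higher number from compound 1 to compound 3 (0.64 log units; beyond the scatter). Compound 4 `CNCCSc1nc(NCc2ccc(-c3ccccn3)cc2)c2[nH]nc(C(C)C)c2n1` has methyl in place of carbamoyl on an amine nitrogen, so 2-ureidoethyl becomes 2-(methylamino)ethyl (methyl in place of carbamoyl on an amine nitrogen). Within the data shown here, no measured compound carries this group. The nearest guide is compound 1, which also has an amine on its sulfur chain and which shows a 4.4-fold higher number from compound 1 to compound 3 (0.64 log units; beyond the scatter). Compound 1 also carries a hydroxyl, so only part of that gap is expected to return. In this assay, the expected change is a 2.2-fold lower number from compound 3 to compound 4 (0.34 log units; beyond the scatter), towards stronger inhibition. Compound 4 is estimated at 110 nM, with an expected range of 40 nM to 300 nM.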

Compound 4, concentration for 50% growth inhibition: 56 nM
Estimate against measurement, compound 4: 2.0-fold (0.29 log units) above; low and high end bracket the measured number.
By their numbers in this assay, from the lowest: compounds 1 and 4 (each within the scatter of the next); then compound 3; then compound 2.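

Placing methyl instead of carbamoyl on the amine nitrogen gives a 4.3-fold lower number from compound 3 to compound 4 (0.63 log units; beyond the scatter) in this assay, so the urea of compound 3 is not needed here. Against the ring-bearing group on sulfur, the same 2-(methylamino)ethyl gives a 10-fold lower number from compound 2 to compound 4 (1.01 log units; beyond the scatter) and so spans the widest gap in this set. The step of a 1.0-fold higher number from compound 1 to compound 4 (0.01 log units; within the scatter) shows that an amine chain without the hydroxyl of compound 1 matches it within the scatter. No measurement here explains these differences. On these data alone, how a plain 2-aminoethyl or a carboxylic acid on the same chain would compare remains open.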